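A few compounds are considered here, and "the series" means these few. Any claim that something is new, unique, unknown or untested is made for them only; others in the source may bear on it.

Compounds measured in an assay on microsomes from intestine for inhibition of acyl-CoA:cholesterol acyltransferase (Oryctolagus cuniculus); on this read-out lower numbers stand for stronger inhibition and higher numbers for weaker inhibition:
compound 1, `CCCCCCCCCCCCCCC(C)OC(=O)NC(=O)Nc1c(C(C)C)cccc1C(C)C`, with 6800 nM;
compound 2, `CC(C)c1cccc(C(C)C)c1OC(=O)NC(=O)OCCCc1ccccc1`, with 660 nM;
compound 3, `CCCCCCCCCCOC(=O)NC(=O)Oc1c(C(C)C)cccc1C(C)C`, with 74 nM.

Compound 3 gives the lowest number of the three. Its nearest neighbour is compound 2, and the step of an 8.9-fold lower number from compound 2 to compound 3 (0.95 log units; beyond the scatter) lies beyond the scatter; compound 1 sits far above both, and its number, with a different linkage and branched chain, shows only that a long chain on its own does not guarantee a low number.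

Compound 4, `CCCCCCCCCCCCCCCCOC(=O)NC(=O)Oc1c(C(C)C)cccc1C(C)C`, has not yet been measured. It differs from compound 3 in one place: hexyl in place of hydrogen on a saturated chain carbon, ten or more bonds along the chain from an oxygen next to a carbonyl group. The change lengthens the chain that carries the carbonate oxygen, reaching a chain length comparable to that of compound 1.

Within the data shown here, only the step from compound 2 to compound 3 bears on this change, and it points toward longer saturated chains giving lower numbers in this assay, though at a modest size. Compound 1 does not bear directly, since it also changes the linkage. For compound 4 a step of a 1.3-fold lower number from compound 3 to compound 4 (0.13 log units; within the scatter) is therefore expected, with the direction uncertain and possibly within the scatter. The estimate for compound 4 in this assay is 55 nM, with a range from 15 nM to 220 nM.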

Compound 4, half-maximal inhibitory concentration: 50 nM
Beside the measured number, compound 4's estimate is 1.1-fold (0.04 log units) above it; the range from low to high includes it.
By their numbers in this assay, from the lowest: compounds 4 and 3 (each within the scatter of the next); then compound 2; then compound 1.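

In this assay, hexyl in place of hydrogen on a saturated chain carbon, ten or more bonds along the chain from an oxygen next to a carbonyl group, gives a 1.5-fold lower number from compound 3 to compound 4 (0.17 log units; within the scatter), so this read-out does not separate compound 3 from compound 4. The earlier compounds shown here offered only a change of phenyl to heptyl, an 8.9-fold lower number from compound 2 to compound 3 (0.95 log units; beyond the scatter), which lies beyond the scatter and says nothing about adding saturated carbons this far out; the new pair shows that this position accepts hexyl with no change that can be told from the scatter. No measurement shown here offers an explanation for this result.

The compounds shown leave open whether a longer chain at this position would still give a number in this range, and whether an amine or a carboxylic acid at the end of the chain would be accepted in the same way. Compound 4 differs from compound 1 in more than one place, so for compound 1 the contribution of its linkage and of its branched chain to 6800 nM cannot be separated.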